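The source may hold more compounds than are shown below. What is called first, only, known or untested is meant among the compounds shown, and "the series" means these compounds.

Compound 1 `CC(C)[C@@H]1CC[C@@H](C)C[C@H]1OC(=O)c1ccccc1Cl` serves as the reference point of this set. In a physicochemical assay for lipophilicity, measured as octanol-water partition (on this read-out higher numbers stand for higher lipophilicity and lower numbers for lower lipophilicity), compound 1 gives 5.34, the highest of the three numbers on hand. Compound 2 `CC(C)[C@@H]1CC[C@@H](C)C[C@H]1OC(=O)/C=C/c1cccc([N+](=O)[O-])c1` gives 5.18 in this assay, a number within the scatter of compound 1, so the two cannot be told apart. Compound 3 `CC(Cl)C(=O)O[C@@H]1C[C@H](C)CC[C@H]1C(C)C` gives 4.04 in this assay, a number beyond the scatter and the furthest from compound 1. Going by the values given here, no pair among the measured compounds differs in a single place, so no step between measured compounds can be read off.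

Compound 4 `CC(C)[C@@H]1CC[C@@H](C)C[C@H]1OC(=O)c1ccccc1Br` has not yet been run in this assay. It differs from compound 1 in one place: bromo in place of chloro on an aromatic carbon. Nothing in the measured set isolates this exchange, so the expectation rests on the change alone. The expected step in this assay is small and upward, a number 0.16 log units higher from compound 1 to compound 4 (within the scatter), and probably not beyond the scatter. Compound 4 is therefore estimated at 5.5 in this assay, within the range 5.2 to 5.8.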

Compound 4, partition coefficient: 5.61
Estimate against measurement, compound 4: 0.11 log units below, and the stated range covers the measured number.
By their numbers in this assay, from the lowest: compound 3; then compounds 2, 1 and 4 (each within the scatter of the next, the first and the last beyond it).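

In this assay, going by these compounds alone, bromo in place of chloro on an aromatic carbon ortho to a large group gives a number 0.27 log units higher from compound 1 to compound 4 (within the scatter), the first step that isolates a single place. At this position on the core of compound 1, the two halogens therefore cannot be told apart on this read-out, and the exchange of one heavy atom for another leaves the hydrogen-bond donor and acceptor counts and the net charge as they were. Nothing on hand bears on the origin of this step.

A single exchange at a single place leaves open how far this aromatic carbon tolerates groups of another kind, such as an amine or a carboxylic acid. On these data alone, whether bromo in place of chloro gives a step of like size on any other aromatic carbon of the series also remains open.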